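The source may report more compounds than this note shows. Statements on the series, on what has been measured and on what is new or still open speak of the compounds shown alone.

Compound 1, `O=C1/C(=C/c2cccc(Cl)c2)CCCc2ccccc21`: 8200 nM in a functional assay on P388 cells (Mus musculus) for inhibition; on this read-out higher numbers stand for weaker inhibition and lower numbers for stronger inhibition
Compound 2, `O=C1/C(=C/c2cccc(Br)c2)CCCc2ccccc21`: 10500 nM in this assay
Compound 3, `O=C1CCCCC/C1=C\c1cccc(Cl)c1`: 25700 nM in this assay

Compound 1 and compound 2 share one core, while compound 3 is built on another; the difference between the two cores is not broken down here. Compound 2 differs from compound 1 by bromo in place of chloro on an aromatic carbon, which gave a 1.3-fold higher number from compound 1 to compound 2 (0.11 log units; within the scatter). Compound 3 has the highest number of the three, beyond the scatter from both compound 1 and compound 2.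

Compound 4, `O=C1CCCCC/C1=C\c1cccc(Br)c1`, is not yet measured in this assay. It differs from compound 3 by bromo in place of chloro on an aromatic carbon, the same kind of change as before, though here the place is meta to a group of 9 heavy atoms rather than meta to a large group. Because the same kind of change gave a 1.3-fold higher number from compound 1 to compound 2 (0.11 log units; within the scatter), a step of similar size is expected, a 1.3-fold higher number from compound 3 to compound 4 (0.11 log units; within the scatter). Compound 4 is therefore estimated at 33000 nM, most likely between 15000 nM and 70000 nM.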

Compound 4, half-maximal inhibitory concentration: 24100 nM
For compound 4 the middle estimate is 1.4-fold (0.14 log units) above the measured one, within the range that was stated.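

In this assay bromo in place of chloro on the aromatic carbon gave a 1.1-fold lower number from compound 3 to compound 4 (0.03 log units; within the scatter) and so stayed within the usual scatter on this second core as well. Set side by side, the two steps do not differ: the same change on two cores in this assay, a 1.3-fold higher number (0.11 log units; within the scatter) from compound 1 to compound 2 and a 1.1-fold lower number (0.03 log units; within the scatter) from compound 3 to compound 4, 1.4-fold (0.14 log units) apart, within the scatter of two such steps. This shows that this one swap carried across these two cores without a detectable difference, but it does not show that other changes would carry across, or that a third core would behave the same way.

On these data alone, it remains open whether a different group at this place, such as an amine, a carboxylic acid or a methoxy group, would shift the number beyond the scatter. As far as these compounds go, it is also open whether either core would respond the same way to such a group.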